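This account rests on a few compounds, and the source may have more. Where it says the series, first, only, none or still open, it means among the compounds named here.

In a functional assay on T47D cells (Homo sapiens) for cytotoxicity, read by sulforhodamine B assay, with a stated time of 48 h (on this read-out higher numbers stand for weaker inhibition and lower numbers for stronger inhibition), compound 1 `NS(=O)(=O)c1ccc(N/C=C\C(=O)c2cc3ccccc3oc2=O)cc1` gives 109000 nM, the higher of the two numbers in hand. Its nearest neighbour, compound 3 `O=C(/C=C\Nc1ccc(S(=O)(=O)Nc2ncccn2)cc1)c1cc2ccccc2oc1=O`, gives 75200 nM in this assay, so the step of a 1.4-fold lower number from compound 1 to compound 3 (0.16 log units; within the scatter) stays within the scatter. In this assay compound 2 `CC(=O)NS(=O)(=O)c1ccc(N/C=C\C(=O)c2cc3ccccc3oc2=O)cc1` gives no result reported. Compound 4 `O=C(/C=C\Nc1ccc(S(=O)(=O)Nc2ccc3cn[nH]c3c2)cc1)c1cc2ccccc2oc1=O` differs from compound 1 by 1H-indazol-6-yl in place of hydrogen on a sulfonamide nitrogen. Among the measured compounds shown here, the only measured step that bears on this change is the one from compound 1 to compound 3, which put pyrimidin-2-yl in place of hydrogen on the same sulfonamide nitrogen and moved the number only within the scatter. Compound 4 is therefore expected to show a step of a 1.3-fold lower number from compound 1 to compound 4 (0.11 log units; within the scatter), nothing beyond the scatter. Compound 4 is estimated at 85000 nM in this assay, with a range from 30000 nM to 250000 nM.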

Compound 4, half-maximal inhibitory concentration: 96500 nM
Compound 4: middle estimate off by 1.1-fold (0.06 log units), on the low side, within the range that was stated.
By their numbers in this assay, from the lowest: compounds 3, 4 and 1 (each within the scatter of the next).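

With 1H-indazol-6-yl on the sulfonamide nitrogen, this assay gives a 1.1-fold lower number from compound 1 to compound 4 (0.05 log units; within the scatter) and so stays level with the unsubstituted sulfonamide. Replacing pyrimidin-2-yl with 1H-indazol-6-yl gives a 1.3-fold higher number from compound 3 to compound 4 (0.11 log units; within the scatter) and likewise separates nothing, so two quite different groups at this position now leave the number where hydrogen left it. Nothing measured here gives a reason for this.

On these data alone, whether a small methyl group, or a longer chain ending in an amine or a carboxylic acid, would move the number beyond the scatter remains open. Compound 2 cannot help here, as it has no reported number.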